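The compounds below may be only part of what the source reports. "The series", "measured", "known", "first", "only" and "open" are said of these compounds alone.

Among the measured compounds shown here, compound 1 `N#Cc1c(N)nc(SCC(N)=O)c(C#N)c1-c1ccc(OCC2CC2)cc1` gives 31% in an assay on CHO cells for displacement of a labelled ligand from adenosine receptor A1 (Homo sapiens), read by scintillation counting, with a stated time of 90 min, tested at 1 uM (on this read-out lower numbers stand for less inhibition and higher numbers for more inhibition at the one concentration tested (going by the name of the read-out)), and stands highest of the two numbers measured so far; nearest is compound 2 `N#Cc1c(N)nc(SCc2nc3ccccc3[nH]2)c(C#N)c1-c1ccc(OCC2CC2)cc1` with 21%, the step of a number 10 percentage points lower from compound 1 to compound 2 (within the scatter) lying within the scatter. Compound 3 `N#Cc1c(N)nc(SCC(N)=O)c(C#N)c1-c1ccc(OCC2CCC2)cc1` differs from compound 1 by cyclobutyl in place of cyclopropyl on a saturated chain carbon bound to an oxygen on an aromatic ring. For the measured compounds named here, the one measured step changes the group on the saturated chain carbon bound to a sulfur, leaving the cyclopropylmethoxy untouched, so no measured step bears on this change. The expected step is no change at the digits printed from compound 1 to compound 3 (within the scatter), none beyond the scatter. Compound 3 is estimated at 31%, within a range from 15% to 47%.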

Compound 3, a percentage reported as inhibition, at one concentration (the size of the read-out at that concentration, not a potency): 1%
Beside the measured number, compound 3's estimate is 30 percentage points above it; measured number below the stated range.
By their numbers in this assay, from the lowest: compound 3; then compounds 2 and 1 (each within the scatter of the next).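

The ether end of the series is not neutral to a small ring change: in this assay, going from the three-membered to the four-membered ring gives a number 30 percentage points lower from compound 1 to compound 3 (beyond the scatter). This is the first step shown beyond the scatter, whereas the change on the saturated chain carbon bound to a sulfur stayed within it. Nothing available accounts for the drop.

Open, on these data alone, is how a plain methoxy or a cyclopentyl group would read at this place. Also open, as far as these compounds go, is whether cyclobutyl has the same effect with 1H-benzimidazol-2-yl in place of carbamoyl.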